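Lengthening the chain from compound 2 to compound 3

A few compounds are considered here, and "the series" means these few. Any claim that something is new, unique, unknown or untested is made for them only; others in the source may bear on it.

In an ADME assay on L6 cells (Rattus norvegicus) for cytotoxicity, read by resazurin assay, with a stated time of 70 h (a lower number here means a stronger inhibitor, a higher number a weaker inhibitor), compound 1 `N=C(N)c1ccc2cc(-c3cccc(OCCCOc4ccccc4)c3)oc2c1` gives 19800 nM and compound 2 `c1ccc(OCCCOc2cccc(-c3cc4ccc(C5=NCCN5)cc4o3)c2)cc1` gives 10100 nM with the two values within the scatter of each other. Among the compounds with values here, the only measured step is a 2.0-fold lower number from compound 1 to compound 2 (0.29 log units; within the scatter) within the scatter, and it leaves the chain untouched. Within the data shown here, compound 3 `c1ccc(OCCCCCOc2cccc(-c3cc4ccc(C5=NCCN5)cc4o3)c2)cc1` carries the change 2-phenoxyethyl in place of phenoxy on a saturated chain carbon, three bonds along the chain from an oxygen on an aromatic ring on the chain, a change that no measured step covers. No shift beyond the scatter is therefore expected in this assay on this evidence. The expected step is a 1.3-fold lower number from compound 2 to compound 3 (0.10 log units; within the scatter) as an estimate only. Compound 3 is estimated at 8000 nM with an expected range from 3000 nM to 20000 nM in this measurement.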

Compound 3, half-maximal inhibitory concentration: 3700 nM
Compound 3: the middle estimate sits 2.2-fold (0.33 log units) above what was measured; measured number inside the range.
By their numbers in this assay, from the lowest: compound 3; then compounds 2 and 1 (each within the scatter of the next).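

In this assay, within the data shown here, the change of phenoxy to 2-phenoxyethyl on a saturated chain carbon gives a 2.7-fold lower number from compound 2 to compound 3 (0.44 log units; beyond the scatter) and is the only step so far beyond the scatter, though a modest one. The chain is therefore the first place in the series shown to move this number, whereas the earlier change on the core did not. No evidence on hand accounts for the shift. Still open, as far as these compounds go, is whether a longer chain, such as 3-phenoxypropyl in place of 2-phenoxyethyl, extends the trend. Also open, from the compounds shown here alone, is whether an amine in place of phenoxy keeps it.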